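A few compounds are considered here, and "the series" means these few. Any claim that something is new, unique, unknown or untested is made for them only; others in the source may bear on it.

Measured so far in a physicochemical assay for solubility, read by HPLC, with a stated time of 20 h, at pH 1; on this read-out higher numbers stand for higher solubility and lower numbers for lower solubility:

- Compound 1 `O=C(O)C[C@H]1CC[C@H](c2ccc(C(=O)Nc3nnc(Cc4ccc(F)cc4)s3)cc2)CC1` gives < 2000 nM, which is a limit.
- Compound 2 `O=C(O)C[C@H]1CC[C@H](c2ccc(C(=O)Nc3nnc(Cc4ccc(F)cc4)o3)cc2)CC1` gives < 2000 nM, which is a limit.
- Compound 3 `O=C(Nc1nc(Cc2ccccc2)no1)c1ccc(O[C@H]2CC[C@@H](C(=O)O)CC2)cc1` gives < 2000 nM, which is a limit.

Compound 3 has no exact number, only the limit < 2000 nM. The measured set as a whole comes down to the limit of < 2000 nM in this assay, at which 3 of the 3 values shown sit. No two of the measured compounds differ in just one place, so no single structural change can yet be read from these results.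

The next compound is compound 4 `O=C(Nc1nc(Cc2cc(F)cc(F)c2)no1)c1ccc(O[C@H]2CC[C@@H](C(=O)O)CC2)cc1`. It differs from compound 3 in one place: 3,5-difluorophenyl in place of phenyl on a saturated chain carbon bound to an aromatic carbon. In words, this is 3,5-difluorophenyl in place of phenyl on a saturated chain carbon bound to an aromatic carbon. Cut one bond further out, the same difference reads benzyl to 3,5-difluorobenzyl.

The expectation here rests on (the limit of < 2000 nM in this assay, at which 3 of the 3 values shown sit). The estimated change, a step that the limit leaves unreadable from compound 3 to compound 4, is expected to stay within the usual scatter of repeated measurements, with no clear direction. The assay is expected to report only a limit again for compound 4. If a number does appear, the estimate for compound 4 is 1200 nM, with an expected range from 300 nM to 2000 nM.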

Compound 4, solubility: < 2000 nM
Compound 4 gave a limit, no number; the forecaster's own chance of this, stated with the estimate: 90%; the middle value does not contradict the limit.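

Compound 3 and compound 4 both give only a limit in this assay, so the step between them cannot be read. All the compounds shown stop at the same point: the limit of < 2000 nM in this assay, at which 4 of the 4 values shown sit.

Left open is how far apart these compounds truly lie on this read-out, and whether going from benzyl to 3,5-difluorobenzyl changes it at all.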